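Dimethoxyphenyl in Place of Phenyl on the Shared Core

This account rests on a few compounds, and the source may have more. Where it says the series, first, only, none or still open, it means among the compounds named here.

Compound 1 `COc1cc(/C=C/C(=O)/C=C/c2ccccc2)ccc1OCc1cn(CCCOc2cc(=O)oc3ccccc23)nn1` is tested in a functional assay on HCT-116 cells (Homo sapiens) for inhibition, read by sulforhodamine B assay, with a stated time of 48 h, tested at 50 uM (on this read-out higher numbers stand for more inhibition of growth at the one concentration tested and lower numbers for less inhibition of growth), and gives 45%. Among the three compounds measured, compound 1 holds the lowest number; compound 3 `COc1cc(/C=C/C(=O)/C=C/c2ccco2)ccc1OCc1cn(CCCCOc2cc(=O)oc3ccccc23)nn1` gives 47%, which lies within the scatter of compound 1, while compound 2 `COc1ccc(/C=C/C(=O)/C=C/c2ccc(OCc3cn(CCOc4cc(=O)oc5ccccc45)nn3)c(OC)c2)cc1OC` gives 82%, well beyond it. Compound 4 `COc1ccc(/C=C/C(=O)/C=C/c2ccc(OCc3cn(CCCOc4cc(=O)oc5ccccc45)nn3)c(OC)c2)cc1OC` has not yet been measured. It differs from compound 1 in one place: 3,4-dimethoxyphenyl in place of phenyl on a double-bonded chain carbon bound to a double-bonded chain carbon. Compound 2 also carries a 3,4-dimethoxyphenyl group and shows the highest number of the three, so a rise beyond the scatter is expected for compound 4, a step estimated at a number 27 percentage points higher from compound 1 to compound 4 (beyond the scatter). For compound 4 the estimate in this assay is 72%, expected to fall between 55% and 88%.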

Compound 4, percent growth inhibition at one concentration: 67%
Compound 4: the middle estimate sits 5 percentage points above what was measured, within the range that was stated.
By their numbers in this assay, from the lowest: compounds 1 and 3 (each within the scatter of the next); then compound 4; then compound 2.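

In this assay, putting 3,4-dimethoxyphenyl in place of phenyl on a double-bonded chain carbon bound to a double-bonded chain carbon gives a number 22 percentage points higher from compound 1 to compound 4 (beyond the scatter). Among these compounds, this is the first reading of this change alone, with the rest of the molecule held fixed, and it shows that growth inhibition responds to the group at this place. Nothing available explains the rise. Going by these compounds, whether both methoxy groups are needed remains open. So does how an amine or a carboxylic acid in the same place would read.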